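Aryl amide variation: from compound 3 to compound 4

The source may report more compounds than this note shows. Statements on the series, on what has been measured and on what is new or still open speak of the compounds shown alone.

Compound 1 `O=C(Nc1cc(Br)cc2c(=O)cc(C(=O)O)oc12)c1ccccc1`, compound 2 `O=C(Nc1cc(Br)cc2c(=O)cc(C(=O)O)oc12)c1ccc(Cl)c(Cl)c1` and compound 3 `N#Cc1ccc(C(=O)Nc2cc(Br)cc3c(=O)cc(C(=O)O)oc23)cc1` share one core and differ only in the group on the carbonyl carbon. In an assay on CHO cells for agonist activity at G protein-coupled receptor GPR35 (Rattus norvegicus), read by a beta-galactosidase reporter and beta-arrestin recruitment, with a stated time of 90 min (on this read-out higher numbers stand for an effect only at larger amounts of compound and lower numbers for an effect already at smaller amounts), compound 1 gives 2750 nM, compound 2 gives 3250 nM and compound 3 gives 2260 nM. Compound 3 holds the lowest of the three numbers, yet the steps of a 1.2-fold lower number from compound 1 to compound 3 (0.09 log units; within the scatter) and a 1.4-fold lower number from compound 2 to compound 3 (0.16 log units; within the scatter) are both within the scatter, as is a 1.2-fold higher number from compound 1 to compound 2 (0.07 log units; within the scatter). Compound 4 `COc1ccc(C(=O)Nc2cc(Br)cc3c(=O)cc(C(=O)O)oc23)cn1` carries 6-methoxypyridin-3-yl in place of 4-cyanophenyl on a carbonyl carbon. Within the data shown here, no measured step swaps a carbon-only ring for a ring with a hetero atom; the three swaps recorded all stayed within the scatter, so for this assay no step beyond the scatter is expected in either direction. Compound 4 is therefore estimated at 2500 nM, with a range from 1200 nM to 5500 nM. The expected step is a 1.1-fold higher number from compound 3 to compound 4 (0.04 log units; within the scatter).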

Compound 4, half-maximal effective concentration: 991 nM
Compound 4: middle estimate off by 2.5-fold (0.40 log units), on the high side; the whole stated range lies above it.
By their numbers in this assay, from the lowest: compound 4; then compounds 3, 1 and 2 (each within the scatter of the next).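

In this assay the group on the carbonyl carbon now produces steps beyond the scatter: 6-methoxypyridin-3-yl gives (a 2.3-fold lower number from compound 3 to compound 4 (0.36 log units; beyond the scatter)) and (a 2.8-fold lower number from compound 1 to compound 4 (0.44 log units; beyond the scatter)) and (a 3.3-fold lower number from compound 2 to compound 4 (0.52 log units; beyond the scatter)). Phenyl, 3,4-dichlorophenyl and 4-cyanophenyl had stayed within the scatter of each other, so compound 4, the only one with a hetero atom in this ring, stands apart from all three. Nothing measured here gives a reason for the step.

The ring nitrogen and the methoxy enter together, so the step cannot be assigned to either. Pyridin-3-yl and 4-methoxyphenyl on the same carbonyl carbon would separate them.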